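Amide for Urea on the Shared Core

A few compounds are considered here, and "the series" means these few. Any claim that something is new, unique, unknown or untested is made for them only; others in the source may bear on it.

Measured compounds:
compound 1 `O=C(Nc1cccc(-n2cc(-c3ccncc3)c(-c3cc(O)cc(Cl)c3)n2)c1)Nc1ccc(Cl)c(C(F)(F)F)c1` — 53%
compound 2 `COc1cc(Cl)cc(-c2nn(-c3cccc(NC(=O)Nc4ccc(Cl)c(C(F)(F)F)c4)c3)cc2-c2ccncc2)c1` — 58%
compound 3 `COc1cc(Cl)cc(-c2nn(-c3cccc(NC(=O)Nc4cc(C(F)(F)F)cc(C(F)(F)F)c4)c3)cc2-c2ccncc2)c1` — 15%

In a functional assay on T47D cells (Homo sapiens) for inhibition, read by sulforhodamine B assay, with a stated time of 48 h, tested at 1 uM (on this read-out lower numbers stand for a stronger effect and higher numbers for a weaker effect at the one concentration tested), compound 2 gives the highest of the three numbers. Compound 1 sits close to it, with a number 5 percentage points higher from compound 1 to compound 2 (within the scatter) on replacing methyl with hydrogen. Going by the values given here, compound 3 gives a much lower number, and no single step links it to compound 2.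

Compound 4 `COc1cc(Cl)cc(-c2nn(-c3cccc(NC(=O)c4cccc(C(F)(F)F)c4)c3)cc2-c2ccncc2)c1` differs from compound 2 by 3-(trifluoromethyl)phenyl in place of (4-chloro-3-(trifluoromethyl)phenyl)amino on a carbonyl carbon. Among the compounds with values here, no measured step changes this part of the molecule, so nothing among the measured steps bears directly on it; the only recorded step, from compound 1 to compound 2, touched another position and stayed within the scatter.

For compound 4 a somewhat higher number is expected, a number 10 percentage points higher from compound 2 to compound 4 (within the scatter), estimated at 68% with a range from 40% to 95%.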

Compound 4, a percentage reported as activity, at one concentration (the size of the read-out at that concentration, not a potency): 92%
The estimate for compound 4 lay 24 percentage points below the measured number, and the stated range covers the measured number.
By their numbers in this assay, from the lowest: compound 3; then compounds 1 and 2 (each within the scatter of the next); then compound 4.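

In this assay, the group on the carbonyl carbon proves to matter: this change gives a number 34 percentage points higher from compound 2 to compound 4 (beyond the scatter), whereas the earlier change on the oxygen stayed within the scatter. The entering 3-(trifluoromethyl)phenyl lacks both the amino nitrogen and the chlorine of the leaving group, so this single step cannot separate the two differences. No available measurement explains the shift. On these data alone, it remains open whether 4-chloro-3-(trifluoromethyl)phenyl placed directly on the carbonyl carbon, or a sulfonamide in place of the carbonyl linkage, would track compound 2 or compound 4.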